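A Heteroaryl Chain Replaces the Aryl End of Compound 2

The source may hold more compounds than are shown below. What is called first, only, known or untested is meant among the compounds shown, and "the series" means these compounds.

Compound 1 `Cc1nn(-c2ncnc3nc[nH]c23)c2c1C(OCC(=O)c1ccc(F)cc1)CC(=O)N2` and compound 2 `Cc1nn(-c2ncnc3nc[nH]c23)c2c1C(OCc1ccc(C(C)C)cc1)CC(=O)N2` share one core and differ only at the end of the ether chain. In a functional assay on HEK293 cells for agonist activity at G-protein coupled receptor 39 (Homo sapiens), read by scintillation proximity assay and inositol phosphate accumulation, with a stated time of 75 min, in the presence of a further agent that is not named here (on this read-out lower numbers stand for an effect already at smaller amounts and higher numbers for an effect only at larger amounts of compound), compound 1 gives 3 nM and compound 2 gives 5 nM. Compound 2 thus holds the higher of the two numbers, yet the step of a 1.7-fold higher number from compound 1 to compound 2 (0.22 log units; within the scatter) stays within the scatter, so the two compounds cannot be ranked against each other.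

Compound 3 `Cc1nn(-c2ncnc3nc[nH]c23)c2c1C(OCCn1nccc1C)CC(=O)N2` carries the change ((5-methyl-1H-pyrazol-1-yl)methyl in place of 4-isopropylphenyl on a saturated chain carbon bound to an oxygen on a saturated carbon). Going by the values given here, the only measured step that touches this position is the one from compound 1 to compound 2, and since a 1.7-fold higher number from compound 1 to compound 2 (0.22 log units; within the scatter) was within the scatter, the data show that this chain end has so far accepted a change of group without a shift beyond the noise. Among the compounds with values here, that single step is the whole basis for the expectation; the entering heteroaryl group has no measured counterpart here.

Compound 3 is therefore expected to lie near its neighbour, with a step of a 2.0-fold higher number from compound 2 to compound 3 (0.30 log units; within the scatter) in this assay, and its estimated value is 10 nM, in a range from 3 nM to 40 nM.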

Compound 3, half-maximal effective concentration: 10 nM
Estimate against measurement, compound 3: no gap at the digits printed, within the range that was stated.
By their numbers in this assay, from the lowest: compounds 1, 2 and 3 (each within the scatter of the next, the first and the last beyond it).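

Replacing 4-isopropylphenyl with (5-methyl-1H-pyrazol-1-yl)methyl gives a 2.0-fold higher number from compound 2 to compound 3 (0.30 log units; within the scatter) in this assay, so at this place, on a saturated chain carbon bound to an oxygen on a saturated carbon, a six-membered aromatic ring of carbon only can give way to a five-membered aromatic ring with 2 hetero atoms without a shift beyond the noise. Going by these compounds alone, the position is not wholly indifferent, however: the change to the same pyrazole group from (4-fluorophenyl)carbonyl gives a 3.3-fold higher number from compound 1 to compound 3 (0.52 log units; beyond the scatter), the first step at this chain end to pass the scatter, though only a modest one. Nothing available here gives a reason for either step.

The compounds shown leave open what the pyrazole ring and its methyl group each contribute, a question that the plain 1H-pyrazol-1-ylmethyl group would address. They also leave open how this chain end would respond to an amine, a carboxylic acid or a longer chain, and whether the modest step seen for the pyrazole group would hold with any of these.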